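A few compounds are considered here, and "the series" means these few. Any claim that something is new, unique, unknown or untested is made for them only; others in the source may bear on it.

Measured so far in a functional assay on the whole organism (strain Wistar albino) for inhibition, with Rattus norvegicus as the target, read by paw edema, with stated times of 1 h and 3 h, at a dose of 0.32 mmol/kg by the intraperitoneal route; on this read-out higher numbers stand for more inhibition at the one dose given (going by the name of the read-out) and lower numbers for less inhibition:

compound 1 `COc1ccc(C(=O)C(CC(=O)c2ccc(Cl)cc2)c2cn(-c3ccc(Cl)cc3)nc2-c2ccc(C)cc2)cc1` gives 23.9%
compound 2 `COc1ccc(C(=O)C(CC(=O)c2ccc(Cl)cc2)c2cn(-c3ccc(Cl)cc3)nc2-c2ccc(OC)cc2)cc1` gives 9.61%
compound 3 `Cc1ccc(-c2nn(-c3ccc(S(N)(=O)=O)cc3)cc2C(CC(=O)c2ccc(Cl)cc2)C(=O)c2ccc(F)cc2)cc1` gives 56.2%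

Compound 1 and compound 2 share one core and differ in a single place: methoxy in place of methyl on an aromatic carbon. The step on this assay is a number 14.3 percentage points lower from compound 1 to compound 2 (beyond the scatter), a drop that lies beyond the scatter, so the methoxy compound reads lower than the methyl compound on this core.

Compound 3 is built on a different core; how that core differs from the core of compound 1 is not broken down here. Its number in this assay is the highest of the three, and both gaps to compound 1 and to compound 2 are beyond the scatter.

Compound 4 `COc1ccc(-c2nn(-c3ccc(S(N)(=O)=O)cc3)cc2C(CC(=O)c2ccc(Cl)cc2)C(=O)c2ccc(F)cc2)cc1` is not yet measured. It differs from compound 3 by methoxy in place of methyl on an aromatic carbon. The place of the change reads the same as for the pair compound 1 and compound 2, so this is the same change, now made on the core of compound 3. Among the compounds with values here, only one earlier instance of it exists, and on another core, so the transfer rests on a single step.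

The step from compound 3 to compound 4 is expected to be a number 14.2 percentage points lower from compound 3 to compound 4 (beyond the scatter), a drop of about the size seen in a number 14.3 percentage points lower from compound 1 to compound 2 (beyond the scatter), with the range widened for the change of core. Compound 4 is estimated at 42%, expected between 28% and 57%.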

Compound 4, a percentage reported as inhibition, in the whole organism at one dose (the size of the read-out at that dose, not a potency): 68.1%
The estimate for compound 4 lay 26.1 percentage points below the measured number, outside the stated range (above it).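

In this assay, replacing 4-methylphenyl with 4-methoxyphenyl on the core of compound 3 gives a number 11.9 percentage points higher from compound 3 to compound 4 (beyond the scatter). Set beside the earlier instance, the step runs the opposite way and does not carry over from one core to the other: the same change on two cores in this assay, a number 14.3 percentage points lower (beyond the scatter) from compound 1 to compound 2 and a number 11.9 percentage points higher (beyond the scatter) from compound 3 to compound 4, 26.2 percentage points apart, beyond the scatter of two such steps This shows that, among these four compounds, neither the direction nor the size of the step from methyl to methoxy can be taken from one core and applied to the other, but with only one pair on each core it does not show which feature of the cores goes with the reversal, nor whether either step would hold for other compounds on the same core.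

The compounds shown leave open whether an ethoxy group, a hydroxyl group or a dimethylamino group at the same place on the aromatic ring would follow the methoxy step on the core of compound 3 or the opposite step on the core of compound 1. Also open, on these data alone, is whether the reversal would persist with a carboxylic acid in place of the sulfonamide, and a pair that differs only in that group would be needed to test this.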